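This account rests on a few compounds, and the source may have more. Where it says the series, first, only, none or still open, it means among the compounds named here.

Measured so far:
compound 1 `c1ccc(-c2noc(-c3cc4ccccc4[nH]3)n2)cc1`; in a functional assay on Jurkat cells (Homo sapiens) for antiproliferative activity, read by WST assay, with a stated time of 72 h (a lower number here means a stronger inhibitor, a higher number a weaker inhibitor), compound 1 gives > 50000 nM, a limit of the assay.
compound 2 `Fc1ccc2[nH]c(-c3nc(-c4ccccc4)no3)cc2c1`; in this assay compound 2 gives 33800 nM.

Going by the values given here, compound 2 carries the only number in this assay; the other value shown is a limit. Compound 3 `O=[N+]([O-])c1ccc2[nH]c(-c3nc(-c4ccccc4)no3)cc2c1` differs from compound 2 by nitro in place of fluoro on an aromatic carbon. Among the compounds with values here, only one measured step bears on it, an at least 1.4-fold lower number from compound 1 to compound 2 (0.17 log units; that floor lies within the scatter), and it starts from a limit (the limit of > 50000 nM in this assay, at which 1 of the 2 values shown sits), so its size is not fixed. No step beyond the scatter is therefore expected; the estimated step is a 1.4-fold lower number from compound 2 to compound 3 (0.13 log units; within the scatter). Compound 3 is expected at 25000 nM, with a range from 8000 nM to 80000 nM.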

Compound 3, half-maximal inhibitory concentration: > 50000 nM
Compound 3: a limit, no number; the forecaster's own chance of this, stated with the estimate: 30%; middle value at least 2.0-fold (0.30 log units) away from the limit.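

In this assay compound 3 gives > 50000 nM, a limit and not a number. Going by these compounds alone, at this aromatic carbon, nitro in place of fluoro shows no gain in the step, which can be read only as a floor: an at least 1.4-fold higher number from compound 2 to compound 3 (0.17 log units; that floor lies within the scatter). The step from compound 1 to compound 3 cannot be read, and compound 2 remains the only compound with a number: the limit of > 50000 nM in this assay, at which 2 of the 3 values shown sit.

Going by these compounds, how far compound 3 lies past its limit remains open. Also open, on these data alone, is whether an amine or a carboxylic acid on this aromatic carbon would give a number in this assay.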